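A few compounds are considered here, and "the series" means these few. Any claim that something is new, unique, unknown or untested is made for them only; others in the source may bear on it.

Measured: compound 1 `C=CC(=O)Nc1cccc(Nc2ncnc3ccc(-c4cnc5ccccc5c4)cc23)c1`, 3500 nM; compound 2 `C/C=C/C(=O)Nc1cccc(Nc2ncnc3ccc(-c4cnc5ccccc5c4)cc23)c1`, 2700 nM.

In a functional assay on Raji cells (Homo sapiens) for inhibition, read by MTT assay, with a stated time of 48 h (on this read-out higher numbers stand for weaker inhibition and lower numbers for stronger inhibition), compound 1 gives 3500 nM, the higher of the two numbers, although a 1.3-fold lower number from compound 1 to compound 2 (0.11 log units; within the scatter). Compound 3 `C=CC(=O)Nc1cc(Nc2ncnc3ccc(-c4cnc5ccccc5c4)cc23)ccc1C` differs from compound 1 by methyl in place of hydrogen on an aromatic carbon. Going by the values given here, no measured step touches this ring; the only step, from compound 1 to compound 2, puts prop-1-en-1-yl in place of vinyl on a carbonyl carbon and stays within the scatter. In this assay compound 3 is therefore expected to show a 1.2-fold lower number from compound 1 to compound 3 (0.07 log units; within the scatter), no change beyond the scatter. Compound 3 is estimated at 3000 nM, range 1200 nM to 8000 nM.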

Compound 3, half-maximal inhibitory concentration: 8500 nM
For compound 3 the middle estimate is 2.8-fold (0.45 log units) below the measured one; the measured number lies above the stated range.
By their numbers in this assay, from the lowest: compounds 2 and 1 (each within the scatter of the next); then compound 3.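

In this assay methyl in place of hydrogen on the aromatic carbon ortho to the (vinylcarbonyl)amino group and para to a large group gives a 2.4-fold higher number from compound 1 to compound 3 (0.39 log units; beyond the scatter) and so weakens inhibition. Going by these compounds alone, this ring position responds to a single added carbon, whereas the only earlier step, made at the carbonyl carbon, stayed within the scatter. Nothing available bears on why the number rises at this position.

From the compounds shown here alone, whether a chlorine, a methoxy group or an ethyl group on the same carbon gives a similar step remains open. Going by these compounds, it is also open whether methyl has the same effect alongside the prop-1-en-1-yl group of compound 2.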